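The source may hold more compounds than are shown below. What is called first, only, known or untested is meant among the compounds shown, and "the series" means these compounds.

In an ADME assay on SH-SY5Y cells (Homo sapiens) for cytotoxicity, read by MTT assay, with a stated time of 72 h (on this read-out higher numbers stand for lower toxicity in this test and lower numbers for higher toxicity in this test), compound 1 (`c1coc(-c2cn3ccccc3n2)c1`) gives > 100000 nM, which is a limit of the assay. Compound 3 (`Nc1cccn2cc(-c3ccco3)nc12`) gives > 100000 nM, also only a limit. For the measured compounds named here, the sole measured step is a step that the two limits leave unreadable from compound 1 to compound 3, so it offers no size to carry forward, and the series is marked by the limit of > 100000 nM in this assay, at which 2 of the 3 values shown sit. Compound 2 (`COc1ccc(-c2cn3cc(-c4ccco4)cc(N)c3n2)cc1OC`), which also carries a phenyl ring, gives a true number of 36400 nM. Compound 4 (`Nc1cc(-c2ccccc2)cn2cc(-c3ccco3)nc12`) differs from compound 3 by phenyl in place of hydrogen on an aromatic carbon. Going by the values given here, with compound 2 at 36400 nM as the only guide, lower numbers, meaning higher toxicity, are expected. The estimated change is an at least 2.2-fold lower number from compound 3 to compound 4 (0.34 log units; beyond the scatter). For compound 4 the estimate is 45000 nM, with an expected range of 15000 nM to 100000 nM.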

Compound 4, half-maximal cytotoxic concentration: 500 nM
Estimate against measurement, compound 4: 90-fold (1.95 log units) above; the whole stated range lies above it.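

In this assay, for the compounds shown here, phenyl in place of hydrogen on an aromatic carbon, meta to an amino group, gives an at least 200-fold lower number from compound 3 to compound 4 (2.30 log units; beyond the scatter), the first step that can be read at all. At this position, the change leads from a compound at the limit to one with a true number, and the step is large. Its full size stays unknown because compound 3 stands at a limit: the limit of > 100000 nM in this assay, at which 2 of the 4 values shown sit.

The compounds shown leave open whether the amino group is needed for this change. They also leave open whether a methyl group or a pyridine ring on the same carbon would act as phenyl does.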